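The source may report more compounds than this note shows. Statements on the series, on what has been measured and on what is new or still open speak of the compounds shown alone.

Measured compounds:
- compound 1, `CCc1cc(Nc2nc(N[C@@H](C)c3ccc(F)cc3)nc3cc(Cl)ccc23)n[nH]1`, 440 nM
- compound 2, `CCc1cc(Nc2nc(N[C@@H](C)c3ccc(Cl)cn3)nc3cccc(OC)c23)n[nH]1`, 3.5 nM
- compound 3, `CCc1cc(Nc2nc(N[C@@H](C)c3ccc(C)cc3)nc3cccc(F)c23)n[nH]1`, 27 nM

All three were tested in an assay on isolated protein for inhibition of G protein-coupled receptor kinase 6 (Homo sapiens), read by scintillation counting, radiometric assay and 33P incorporation, with a stated time of 80 min, in the presence of a further agent that is not named here; a higher number here means a weaker inhibitor, a lower number a stronger inhibitor. Compound 2 gives the lowest number of the three in this assay: compound 3 sits a good deal higher, and compound 1 much higher still, both gaps well beyond the ordinary scatter of the measurement. The three compounds differ in more than one place at once, so no single change can be credited for these gaps.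

Compound 4, `CCc1cc(Nc2nc(NCc3ccc(Cl)cc3)nc3cccc(OC)c23)n[nH]1`, is not yet measured. It is built from compound 2 by one change: a group of 8 heavy atoms (7 carbon, 1 chlorine; one six-membered aromatic ring of carbon only) in place of a group of 9 heavy atoms (7 carbon, 1 nitrogen, 1 chlorine; one six-membered aromatic ring with 1 hetero atom), on a nitrogen on an aromatic ring. Two features go at once: the ring nitrogen, and the stereocentre with its methyl branch on the carbon that links the ring to the nitrogen. Going by the values given here, no measured pair shows this step alone, so the expectation rests on general experience rather than on a step within this set. Removing a branch that sets a defined stereocentre, and exchanging a ring with a nitrogen for an all-carbon ring, more often costs than gains in this kind of assay. A loss of potency beyond the scatter is therefore expected, with the step of an 8.6-fold higher number from compound 2 to compound 4 (0.93 log units; beyond the scatter) from compound 2 to compound 4. Compound 4 is estimated at 30 nM, with a likely range from 8 nM to 120 nM.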

Compound 4, half-maximal inhibitory concentration: 16 nM
Compound 4: the middle estimate sits 1.9-fold (0.27 log units) above what was measured, within the range that was stated.
By their numbers in this assay, from the lowest: compound 2; then compounds 4 and 3 (each within the scatter of the next); then compound 1.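

In this assay, going by these compounds alone, this is the first step in the set that changes only one place, the group on a nitrogen on an aromatic ring, and it puts a size on that place: a 4.6-fold higher number from compound 2 to compound 4 (0.66 log units; beyond the scatter) is a modest loss, though beyond the scatter. Three things leave together when 4-chlorobenzyl enters, namely the ring nitrogen, the methyl branch and the defined stereocentre, yet compound 4 still gives 16 nM and so remains a clear inhibitor without any of them. Nothing available here bears on why the step has this size.

What stays open is how the step divides among these features, and only a group that keeps the ring nitrogen but loses the branch, or keeps the branch but loses the ring nitrogen, could separate them. Also open, going by these compounds, is how this place responds to other groups, such as an ethyl or a hydroxymethyl in place of the methyl branch, or a fluorine or a methoxy in place of the chlorine on the ring.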